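Proline amide series: pyridylmethyl replaced by hydroxy ester chain

The source may report more compounds than this note shows. Statements on the series, on what has been measured and on what is new or still open speak of the compounds shown alone.

Three compounds have been run in an assay on isolated protein for inhibition of Rho-associated protein kinase 2 (Homo sapiens), read by HTRF, tested at 10 uM; on this read-out lower numbers stand for less inhibition and higher numbers for more inhibition at the one concentration tested (going by the name of the read-out). Compound 1 `Cc1cccc(Oc2ccnc(N3CCC[C@H]3C(=O)NCc3cccnc3)n2)c1` gives 0% in this assay. Compound 2 `CN(CCCn1ccnc1)C(=O)[C@@H]1CCCN1c1nccc(Nc2ccccc2)n1` gives 1%, and compound 3 `Cc1cccc(Nc2ncnc3c2CN(C(=O)c2ccc(N(C)C)c4ccccc24)CC3)c1` gives 1%. Among the measured compounds shown here, compound 1 sits at the bottom of the three figures, but compound 2 and compound 3 both fall within the usual scatter of it, so the three readings cannot be told apart; the whole set is flat at the single concentration tested, and no pair differs in one place only, so no measured step exists in this assay.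

Compound 4 `COC(=O)C(CO)NC(=O)[C@@H]1CCCN1c1nccc(Oc2cccc(C)c2)n1` has not yet been measured. It differs from compound 1 by 2-hydroxy-1-(methoxycarbonyl)ethyl in place of (pyridin-3-yl)methyl on an amide-type nitrogen. For the measured compounds named here, nothing measured so far shows what an exchange of this kind on the amide-type nitrogen does to the read-out, and the three values present give no foothold for a direction.

Going by the values given here, with compound 1 at 0% and no measured step to lean on, the expectation for compound 4 is a step from a number 2 percentage points higher from compound 1 to compound 4 (within the scatter) that stays within the scatter, with no direction claimed. Compound 4 is therefore estimated at 2%, within a range from 0% to 12% in this assay.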

Compound 4, a percentage reported as inhibition, at one concentration (the size of the read-out at that concentration, not a potency): 0%
Beside the measured number, compound 4's estimate is 2 percentage points above it; low and high end bracket the measured number.
By their numbers in this assay, from the lowest: compounds 1, 4, 2 and 3 (each within the scatter of the next).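

In this assay, among the compounds shown here, 2-hydroxy-1-(methoxycarbonyl)ethyl in place of (pyridin-3-yl)methyl on the amide-type nitrogen gives no change at the digits printed from compound 1 to compound 4 (within the scatter) and is the only measured step at this position. The exchange removes the six-membered aromatic ring with its hetero atom and brings in a ringless group with a hydrogen-bond donor and more hydrogen-bond acceptors, yet this read-out at its one tested concentration does not separate the two groups. With both compounds at the bottom of the measured figures, the step shows no gain from this exchange, but it cannot show whether either group would matter in a compound with clear inhibition, and no available evidence accounts for the flat result.

Still open, on these data alone, is whether a basic amine, a free carboxylic acid in place of the methyl ester, or a longer chain on the amide-type nitrogen would move this assay clear of the scatter. The compounds shown also leave open whether changes elsewhere on the core of compound 1 would give this position a readable effect.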